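A few compounds are considered here, and "the series" means these few. Any claim that something is new, unique, unknown or untested is made for them only; others in the source may bear on it.

Measured compounds:
- compound 1, `CN(C)CCn1cnnc1-c1cc(Oc2ccc(NC(=O)N/N=C/c3ccc(O)cc3)cc2F)ccn1`: 3560 nM
- compound 2, `CN(C)CCn1cnnc1-c1cc(Oc2ccc(NC(=O)N/N=C/c3c(Cl)cccc3Cl)cc2F)ccn1`: 1410 nM
- compound 3, `COc1cc(/C=N/NC(=O)Nc2ccc(Oc3ccnc(-c4nncn4CCN(C)C)c3)c(F)c2)ccc1O`: > 100000 nM

In a functional assay on A549 cells (Homo sapiens) for cytotoxicity, read by MTT assay, with a stated time of 72 h (on this read-out higher numbers stand for weaker inhibition and lower numbers for stronger inhibition), compound 1 gives 3560 nM, the highest of the two numbers shown. Compound 2 gives 1410 nM. For compound 3 the assay reports only a limit, > 100000 nM, and no number (the limit of > 100000 nM in this assay, at which 1 of the 3 values shown sits).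

Compound 4, `CN(C)CCn1cnnc1-c1cc(Oc2ccc(NC(=O)N/N=C/c3ccc(O)cc3O)cc2F)ccn1`, has not been measured. It differs from compound 1 by hydroxy in place of hydrogen on an aromatic carbon, the new group sitting ortho to a large group and meta to a hydroxy group.

For the measured compounds named here, two measured steps bear on this. Swapping the whole ring, a 2.5-fold lower number from compound 1 to compound 2 (0.40 log units; beyond the scatter), gave a modest gain. Adding a single group to the same ring, an at least 28-fold higher number from compound 1 to compound 3 (1.44 log units; beyond the scatter), pushed the value to the limit, a large loss; an at least 70-fold higher number from compound 2 to compound 3 (1.85 log units; beyond the scatter) tells the same story from compound 2. Going by the values given here, a hydroxy entering the ring of compound 1 is closer in kind to the change that led to compound 3 than to the one that led to compound 2, so a step toward weaker inhibition is expected, though smaller than for the methoxy.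

Compound 4 is therefore expected to give 7000 nM in this assay, between 1500 nM and 40000 nM, a step of a 2.0-fold higher number from compound 1 to compound 4 (0.29 log units; within the scatter).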

Compound 4, half-maximal inhibitory concentration: 12700 nM
Estimate against measurement, compound 4: 1.8-fold (0.26 log units) below, within the range that was stated.
By their numbers in this assay, from the lowest: compound 2; then compound 1; then compound 4. At a limit, above all of these: compound 3.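

In this assay, a hydroxy on the aromatic carbon ortho to a large group and meta to a hydroxy group weakens inhibition, with a 3.6-fold higher number from compound 1 to compound 4 (0.55 log units; beyond the scatter), and a 9.0-fold higher number from compound 2 to compound 4 (0.95 log units; beyond the scatter) widens the distance to the 2,6-dichlorophenyl compound, so this ring position is not neutral to a small added group. Even so, the loss stops short of what the 4-hydroxy-3-methoxyphenyl ring gave, with an at least 7.8-fold lower number from compound 3 to compound 4 (0.89 log units; beyond the scatter), which shows that adding a group to the 4-hydroxyphenyl ring does not always abolish measurable activity. The result for compound 3 is a limit and not a number, so the true size of that gap remains unknown: the limit of > 100000 nM in this assay, at which 1 of the 4 values shown sits.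

Compound 3 and compound 4 differ in both the added group and its place on the ring, so these compounds cannot separate the effect of one from the other. On these data alone, it also stays open how an amine, a fluorine or a methoxy on the same carbon as the new hydroxy would compare with compound 1.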